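The source may hold more compounds than are shown below. What is called first, only, known or untested is meant among the compounds shown, and "the series" means these compounds.

Measured in a functional assay on HCT-116 cells (Homo sapiens) for antiproliferative activity, read by MTT assay, with a stated time of 72 h; a lower number here means a stronger inhibitor, a higher number a weaker inhibitor:
- compound 1 `C=CC(=O)Nc1nc(-c2ccccc2)cs1`: 18600 nM
- compound 2 `C=CC(=O)Nc1nc(-c2ccc(C)cc2)cs1`: 15300 nM

Compound 1 stands within the scatter of compound 2, as a 1.2-fold lower number from compound 1 to compound 2 (0.08 log units; within the scatter) shows. Compound 3 `C=CC(=O)N(CC(=O)NC1COC1)c1nc(-c2ccccc2)cs1` follows from compound 1 by a group of 8 heavy atoms (5 carbon, 1 nitrogen, 2 oxygen; one four-membered non-aromatic ring with 1 hetero atom) in place of a hydrogen atom, on an amide-type nitrogen. Among the compounds with values here, the one measured step lies on an aromatic carbon, not on the amide-type nitrogen, so it gives no size or direction for this change. The value of compound 1, 18600 nM, is therefore the only anchor, and no step beyond the scatter is expected in this assay. The estimated step is a 1.3-fold lower number from compound 1 to compound 3 (0.12 log units; within the scatter). For compound 3 the expected value is 14000 nM, with an estimated range of 4000 nM to 45000 nM.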

Compound 3, half-maximal inhibitory concentration: 20800 nM
Compound 3: middle estimate off by 1.5-fold (0.17 log units), on the low side; low and high end bracket the measured number.
By their numbers in this assay, from the lowest: compounds 2, 1 and 3 (each within the scatter of the next).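

In this assay, the group of 8 heavy atoms in place of the hydrogen on the amide-type nitrogen gives a 1.1-fold higher number from compound 1 to compound 3 (0.05 log units; within the scatter), so compound 1 and compound 3 cannot be told apart. Within the data shown here, this is the first reading at this nitrogen, and a substituent of this size carrying a four-membered non-aromatic ring is compatible with a number in the same range. No supporting data bear on this result.

From the compounds shown here alone, whether a methyl or a longer chain ending in an amine or a carboxylic acid on this nitrogen would give a step beyond the scatter remains open. Also open, going by these compounds, is how the same group reads on the core of compound 2.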